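The source may hold more compounds than are shown below. What is called first, only, known or untested is meant among the compounds shown, and "the series" means these compounds.

Four compounds share a common skeleton and are compared in a functional assay on MKN-45 cells (Homo sapiens) for cytotoxicity, read by MTT assay, with a stated time of 72 h; on this read-out lower numbers stand for stronger inhibition and higher numbers for weaker inhibition. Compound 1 `CN(C)CCNc1nc(-c2ccc(NC(=O)Nc3ccc(Cl)cc3Cl)cc2)nc2ccsc12` gives 2360 nM. Compound 2 `Cc1ccc(NC(=O)Nc2ccc(-c3nc(NCCN(C)C)c4sccc4n3)cc2)cc1` gives 2380 nM. The single difference between these two is 4-methylphenyl in place of 2,4-dichlorophenyl on an amide-type nitrogen, and the step it made is a 1.0-fold higher number from compound 1 to compound 2 (0.00 log units; within the scatter). Compound 3 `CCN(CC)CCNc1nc(-c2ccc(NC(=O)Nc3ccc(Cl)cc3Cl)cc2)nc2c(Cl)c(Cl)sc12` gives 1770 nM in this assay; this number and those of compounds 1 and 2 all lie within the usual scatter of one another, so none of the three stands apart. Compound 3 carries a different core from compound 1, and the difference between the two cores is not broken down here.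

Compound 4 `CCN(CC)CCNc1nc(-c2ccc(NC(=O)Nc3ccc(C)cc3)cc2)nc2c(Cl)c(Cl)sc12` has not yet been measured. Its difference from compound 3 is 4-methylphenyl in place of 2,4-dichlorophenyl on an amide-type nitrogen, which is the same change as the one separating compound 1 from compound 2, at the same kind of place with the same neighbour, and it occurs twice among these four compounds. The coming step is expected to be a 1.0-fold higher number from compound 3 to compound 4 (0.01 log units; within the scatter), to be set beside the earlier step, because a 1.0-fold higher number from compound 1 to compound 2 (0.00 log units; within the scatter) shows that this change left the number essentially unmoved. That expectation rests on one measured pair only, on a different core, so it is held loosely. Compound 4 is accordingly estimated at 1800 nM in this assay, with a likely range from 900 nM to 3600 nM.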

Compound 4, half-maximal inhibitory concentration: 1450 nM
Compound 4: the middle estimate sits 1.2-fold (0.09 log units) above what was measured, and the stated range covers the measured number.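

In this assay, putting 4-methylphenyl in place of 2,4-dichlorophenyl on the amide-type nitrogen gives a 1.2-fold lower number from compound 3 to compound 4 (0.09 log units; within the scatter), so on this second core the swap again leaves no change that can be told from ordinary repeat-to-repeat variation. Set beside the earlier step, the two results agree: the same change on two cores in this assay, a 1.0-fold higher number (0.00 log units; within the scatter) from compound 1 to compound 2 and a 1.2-fold lower number (0.09 log units; within the scatter) from compound 3 to compound 4, 1.2-fold (0.09 log units) apart, within the scatter of two such steps. Among the compounds shown here, this shows that, for these two cores and this cell assay, the swap made no measurable difference on either one, but with only two pairs it does not show that the same would hold on any other core, and it gives no reason for the result or any sign that the two groups would match in a different test.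

The compounds shown also leave open whether any group on the amide-type nitrogen would shift the number beyond the scatter, for instance a phenyl ring carrying a carboxylic acid, a pyridine ring or a plain cyclohexyl ring. They likewise leave open how much the core and the amine end of the side chain each contribute, and whether a morpholine or a longer chain at that end would matter.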